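This account rests on a few compounds, and the source may have more. Where it says the series, first, only, none or still open, it means among the compounds named here.

Three hydrazone analogues sharing one core have been measured in a functional assay (Mus musculus, strain BALB/C) for inhibition, read by MTT assay, with stated times of 24 h and 72 h; on this read-out higher numbers stand for weaker inhibition and lower numbers for stronger inhibition. Compound 1 `Cc1ccc(C(=O)N/N=C/c2ccccc2F)c(O)c1` gives 42100 nM, the highest of the three numbers. Among the compounds with values here, compound 3 `Cc1ccc(C(=O)N/N=C/c2cccc(Cl)c2)c(O)c1`, which also bears a single chloro group, gives 24400 nM, a number that lies within the scatter of the one for compound 1, so no order between these two can be claimed. Compound 2 `Cc1ccc(C(=O)N/N=C/c2cc(Cl)cc(Cl)c2O)c(O)c1` gives 1510 nM, well beyond the scatter below the number for compound 1.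

The unmeasured compound 4 `Cc1ccc(C(=O)N/N=C/c2ccccc2Cl)c(O)c1` differs from compound 1 in a single place: chloro in place of fluoro on an aromatic carbon. Within the data shown here, no step between measured compounds matches this exchange. Since compound 3, carrying a chloro group in place of any fluoro, gives 24400 nM and so sits within the scatter of compound 1, the step from compound 1 to compound 4 in this assay is expected to be small and is not expected to go beyond the scatter in either direction, with a slight lean toward a lower number.

Compound 4 is therefore estimated at 30000 nM, within a range of 10000 nM to 90000 nM, which corresponds to an expected step of a 1.4-fold lower number from compound 1 to compound 4 (0.15 log units; within the scatter).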

Compound 4, half-maximal inhibitory concentration: 19200 nM
The estimate for compound 4 lay 1.6-fold (0.19 log units) above the measured number; the measured number falls inside the stated range.
By their numbers in this assay, from the lowest: compound 2; then compounds 4, 3 and 1 (each within the scatter of the next, the first and the last beyond it).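

In this assay, the exchange of fluoro for chloro on an aromatic carbon ortho to a large group gives a 2.2-fold lower number from compound 1 to compound 4 (0.34 log units; beyond the scatter), the first step read directly at this position. It shows that this position is not indifferent to which halogen it carries, although the change is modest and leaves compound 4 far from the number of compound 2, which differs from it in more than one place. The data offer no measurement that would explain why chloro gives the lower number here.

From the compounds shown here alone, whether a bromo, methoxy or amine group at this position would continue the step or reverse it remains open. With only fluoro and chloro compared here, a single step sets no trend, and what separates compound 2 from the others cannot be assigned to any one group.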